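The compounds below may be only part of what the source reports. "The series", "measured", "known", "first", "only" and "open" are said of these compounds alone.

Compound 1 `O=C(CN1C(=O)/C(=C/c2ccc(-c3ccc(Cl)cc3)o2)SC1=S)NCc1ccc(C(F)(F)F)cc1`: 170000 nM
Compound 2 `N#Cc1ccc(NC(=O)CN2C(=O)/C(=C/c3ccc(-c4ccc(Cl)cc4)o3)SC2=S)cc1`: 90000 nM
Compound 3 `N#Cc1cc(NC(=O)CN2C(=O)/C(=C/c3ccc(-c4ccc(Cl)cc4)o3)SC2=S)ccc1C(F)(F)F`: the assay returned only a limit

The three measured compounds share one core and differ only in the group on the amide-type nitrogen. In a functional assay on REH cells (Homo sapiens) for cytotoxicity, read by MTT assay, with a stated time of 72 h (a lower number here means a stronger inhibitor, a higher number a weaker inhibitor), compound 1 gives 170000 nM. Compound 2 gives 90000 nM, and the change from compound 1 to compound 2 was a 1.9-fold lower number from compound 1 to compound 2 (0.28 log units; within the scatter). For compound 3 the assay gives no number but a limit, > 250000 nM (the limit of > 250000 nM in this assay, at which 1 of the 3 values shown sits). Compound 3 therefore stands at the weak end of the numbers shown, without an exact value.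

The unmeasured compound 4 `Cc1ccc(CNC(=O)CN2C(=O)/C(=C/c3ccc(-c4ccc(Cl)cc4)o3)SC2=S)cc1` differs from compound 3 in one place: 4-methylbenzyl in place of 3-cyano-4-(trifluoromethyl)phenyl on an amide-type nitrogen. The measured steps that bear on this are the two leading into compound 3, an at least 1.4-fold higher number from compound 1 to compound 3 (0.16 log units; that floor lies within the scatter) and an at least 2.7-fold higher number from compound 2 to compound 3 (0.44 log units; beyond the scatter). Compound 4 resembles compound 1, whose 4-(trifluoromethyl)benzyl likewise sits on the amide-type nitrogen, so the step is expected to run the other way and lower the number: an at least 1.6-fold lower number from compound 3 to compound 4 (0.22 log units; that floor lies within the scatter). Compound 4 is thus expected to give about 150000 nM, within a range from 60000 nM to 300000 nM.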

Compound 4, half-maximal inhibitory concentration: 45000 nM
For compound 4 the middle estimate is 3.3-fold (0.52 log units) above the measured one; measured number below the stated range.
By their numbers in this assay, from the lowest: compounds 4, 2 and 1 (each within the scatter of the next, the first and the last beyond it). At a limit, above all of these: compound 3.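

Putting methyl in place of trifluoromethyl on an aromatic carbon, with the benzyl group otherwise unchanged, moves the number by more than the scatter (a 3.8-fold lower number from compound 1 to compound 4 (0.58 log units; beyond the scatter)), so the group on that carbon matters on its own. Placing 4-methylbenzyl on the amide-type nitrogen does not separate compound 4 from the 4-cyanophenyl compound (a 2.0-fold lower number from compound 2 to compound 4 (0.30 log units; within the scatter)), but it does separate it from the 3-cyano-4-(trifluoromethyl)phenyl compound (an at least 5.5-fold lower number from compound 3 to compound 4 (0.74 log units; beyond the scatter)). The size of that last step is only a floor, since compound 3 has a limit and not a number: the limit of > 250000 nM in this assay, at which 1 of the 4 values shown sits.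

The compounds shown leave open whether a methoxy group or a plain hydrogen on that aromatic carbon would behave like methyl or like trifluoromethyl. They also leave open how an amine or a carboxylic acid on the benzyl group would change the number.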